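A 1,3-thiazol-2-yl group gives way to 1H-1,2,3-triazol-1-yl

The compounds below may be only part of what the source reports. "The series", "measured", "known", "first", "only" and "open" are said of these compounds alone.

In a physicochemical assay for lipophilicity (on this read-out higher numbers stand for higher lipophilicity and lower numbers for lower lipophilicity), compound 1 `Cc1nc(-c2cc(C(F)(F)F)ccc2[C@H]2CCOc3cc(S(=O)(=O)Nc4ccncn4)ccc32)co1` stands as "not determined" (no result reported) and offers no number to work with. Within the data shown here, compound 2 `O=S(=O)(Nc1nccs1)c1ccc2c(c1)OCC[C@H]2c1ccc(C(F)(F)F)cc1-c1nccs1` reads 3.3 and so holds the only value shown, with nothing to rank it against. Compound 3 `O=S(=O)(Nc1nccs1)c1ccc2c(c1)OCC[C@H]2c1ccc(C(F)(F)F)cc1-n1ccnn1` has yet to be measured and departs from compound 2 in one place 1H-1,2,3-triazol-1-yl in place of 1,3-thiazol-2-yl on an aromatic carbon where 1H-1,2,3-triazol-1-yl stands in place of 1,3-thiazol-2-yl on an aromatic carbon, ortho to a large group and meta to a trifluoromethyl group. Among the measured compounds shown here, no pair of measured compounds shows what such an exchange does, so the expectation rests on the structural change alone. A downward move beyond the usual scatter is expected, and a number 0.70 log units lower from compound 2 to compound 3 (beyond the scatter) is the estimated size of it in this assay for this exchange. For compound 3 the estimate is 2.6 with an expected range from 2.2 to 3 on repeated measurement.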

Compound 3, distribution coefficient: 2.3
The estimate for compound 3 lay 0.30 log units above the measured number, within the range that was stated.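

In this assay the exchange of 1,3-thiazol-2-yl for 1H-1,2,3-triazol-1-yl gives a number 1.00 log units lower from compound 2 to compound 3 (beyond the scatter) and so puts a measured size on a change that previously had none. It also shows that the read-out responds to which five-membered aromatic ring stands on this aromatic carbon, ortho to a large group and meta to a trifluoromethyl group, while the rest of the molecule stays the same. Nothing measured here accounts for the size of this step.

From the compounds shown here alone, whether the exchange would give a similar step in another molecule stays open, as this single pair of compounds is the only one that carries it. Also open, going by these compounds, is where an amine, a carboxylic acid or a longer chain on this aromatic carbon would fall in this assay relative to compound 2 and compound 3.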